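A few compounds are considered here, and "the series" means these few. Any claim that something is new, unique, unknown or untested is made for them only; others in the source may bear on it.

Notes on the series, read in a physicochemical assay for permeability, using PAMPA (on this read-out lower numbers stand for lower permeability and higher numbers for higher permeability), as the only measure so far. Compound 1 (`Cc1ccccc1-c1nc(CN2CCC(C(=O)NCCCN3CCC(C)(C)CC3)CC2)c(C)o1`) gives 241 10^-6 cm/s and compound 2 (`Cc1ccccc1-c1nc(CN2CCC(C(=O)NCCCN3CCC(C)CC3)CC2)c(C)o1`) gives 425 10^-6 cm/s in this measure. Compound 3 (`Cc1ccccc1-c1nc(CN2CCC(C(=O)NCCCN3CCCC(C(C)C)C3)CC2)c(C)o1`) has no number: its result stands as "not determined" (no result reported) and so offers no measured starting point. Compound 4 (`Cc1ccccc1-c1nc(CN2CCC(C(=O)NCCN3C[C@H](C)C[C@H](C)C3)CC2)c(C)o1`) differs from compound 3 as follows: a group of 8 heavy atoms (7 carbon, 1 nitrogen; one six-membered non-aromatic ring with 1 hetero atom) in place of a group of 10 heavy atoms (9 carbon, 1 nitrogen; one six-membered non-aromatic ring with 1 hetero atom), on a saturated chain carbon, two bonds along the chain from an amide-type nitrogen with 3,5-dimethylpiperidin-1-yl as the group that enters, on a saturated chain carbon, two bonds along the chain from an amide-type nitrogen.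

Among the compounds with values here, only one measured step comes near this change: a 1.8-fold higher number from compound 1 to compound 2 (0.25 log units; within the scatter) with hydrogen in place of methyl on a saturated ring carbon. That step stays within the scatter, but it is a far smaller exchange than the replacement of a whole group, so it bears on the present change only loosely. Nothing measured points to a step beyond the scatter in either direction in this assay and none is expected. The expectation therefore rests on the level shared by compound 1 at 241 10^-6 cm/s and compound 2 at 425 10^-6 cm/s in the absence of a value for compound 3. Compound 4 is expected at 320 10^-6 cm/s with an estimated range from 140 10^-6 cm/s to 700 10^-6 cm/s in this measure.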

Compound 4, apparent permeability: 712 10^-6 cm/s
Compound 4: the middle estimate sits 2.2-fold (0.35 log units) below what was measured, outside the stated range (above it).
By their numbers in this assay, from the lowest: compounds 1, 2 and 4 (each within the scatter of the next, the first and the last beyond it).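

In this assay, within the data shown here, 3,5-dimethylpiperidin-1-yl entering on a saturated chain carbon, two bonds along the chain from an amide-type nitrogen, gives a 3.0-fold higher number from compound 1 to compound 4 (0.47 log units; beyond the scatter) when it replaces (4,4-dimethylpiperidin-1-yl)methyl, the only step so far to leave the scatter, while replacing (4-methylpiperidin-1-yl)methyl gives a 1.7-fold higher number from compound 2 to compound 4 (0.22 log units; within the scatter). Compound 3 has no number, so the step from it to compound 4 cannot be read, and the exchange of a whole group at this position can be judged only against compound 1 and compound 2, with the reading depending on which of the two serves as reference. No measurement available here accounts for the value of compound 4.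

Each of these exchanges alters the methyl groups on the ring and the chain carbon of the leaving group together, so what each alteration contributes remains unresolved, and (3,5-dimethylpiperidin-1-yl)methyl at the same place would separate them. As far as these compounds go, how a morpholine or an unsubstituted piperidin-1-yl at this position would read in this assay also remains open, as does the role of the two defined stereocentres of the entering group.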